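Sulfonyl substituent change on the most potent analogue

The source may report more compounds than this note shows. Statements on the series, on what has been measured and on what is new or still open speak of the compounds shown alone.

Compound 3 `O=C(NCc1ccc(S(=O)(=O)C2CCC(F)(F)CC2)cc1)N1Cc2ccncc2C1` gives 13 nM in a functional assay on A2780 cells (Homo sapiens) for cytotoxicity, read by sulforhodamine B assay, with a stated time of 72 h (on this read-out higher numbers stand for weaker inhibition and lower numbers for stronger inhibition), the lowest of the two numbers in hand. Compound 1 `O=C(NCc1ccc(S(=O)(=O)c2ccccc2)cc1)NCc1cccnc1` gives 610 nM in this assay, the nearest number, a large gap beyond the scatter. Compound 2 `O=C(NCc1ccc(S(=O)(=O)c2ccccc2)cc1)N1Cc2cccnc2C1` in this assay reaches only > 2000 nM, a limit and not a number. Going by the values given here, the single measured step, an at least 3.2-fold higher number from compound 1 to compound 2 (0.51 log units; beyond the scatter), concerns the group on the carbonyl carbon, and its full size is hidden by the limit of > 2000 nM in this assay, at which 1 of the 3 values shown sits.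

Compound 4 `O=C(NCc1ccc(S(=O)(=O)N2CCC[C@H](O)C2)cc1)N1Cc2ccncc2C1` differs from compound 3 by 3-hydroxypiperidin-1-yl in place of 4,4-difluorocyclohexyl on a sulfonyl sulfur. Among the compounds with values here, no measured step touches the sulfonyl sulfur, so the carbonyl-side step gives no direct guide, and the expectation rests on compound 3 alone, with the uncertainty that a change of ring type and the arrival of a hydroxyl bring. For compound 4 a modest drift toward weaker inhibition is expected, a 3.8-fold higher number from compound 3 to compound 4 (0.59 log units; beyond the scatter). The estimate for compound 4 in this assay is 50 nM, with a range from 10 nM to 300 nM.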

Compound 4, half-maximal inhibitory concentration: 150 nM
Estimate against measurement, compound 4: 3.0-fold (0.48 log units) below; measured number inside the range.
By their numbers in this assay, from the lowest: compound 3; then compound 4; then compound 1. At a limit, above all of these: compound 2.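

Going by these compounds alone, the sulfonyl sulfur position is sensitive: with the carbonyl side held constant, 3-hydroxypiperidin-1-yl in place of 4,4-difluorocyclohexyl gives a 12-fold higher number from compound 3 to compound 4 (1.06 log units; beyond the scatter) in this assay, the first measured step at this position. This single step changes the ring type, removes the two fluorines and adds a hydroxyl, so it cannot be assigned to any one of these changes. Nothing measured on these compounds gives a cause for the step.

Plain piperidin-1-yl, 4,4-difluoropiperidin-1-yl and the mirror-image 3-hydroxypiperidin-1-yl would separate these changes, and their place in the order remains open. Also open, from the compounds shown here alone, is how phenyl on the sulfonyl sulfur reads with the carbonyl-side group shared by compound 3 and compound 4, as the phenyl-bearing compound 1 and compound 2 carry other groups there.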